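Ethoxy in place of methoxy at an assay limit

A few compounds are considered here, and "the series" means these few. Any claim that something is new, unique, unknown or untested is made for them only; others in the source may bear on it.

Measured in a functional assay on Jurkat cells (Homo sapiens) for antiproliferative activity, read by MTT assay, with a stated time of 72 h; on this read-out lower numbers stand for stronger inhibition and higher numbers for weaker inhibition:
- compound 1 `COc1cc(-n2ncnc2-c2ccccc2)cc(OC)c1OC`: > 10000 nM, a limit
- compound 2 `COc1ccccc1-c1ncnn1-c1cc(OC)c(OC)c(OC)c1`: > 10000 nM, a limit

Compound 2 has no exact value: in this assay compound 2 reads > 10000 nM, which is a limit of the assay and not a number. Compound 1 gives no number either, as the limit of > 10000 nM in this assay, at which 2 of the 2 values shown sit, shows.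

Compound 3 `CCOc1ccccc1-c1ncnn1-c1cc(OC)c(OC)c(OC)c1` turns the methoxy of compound 2 into ethoxy: methyl in place of hydrogen on a saturated chain carbon bound to an oxygen on an aromatic ring.

For the measured compounds named here, only one measured step bears on this change, the swap of hydrogen for methoxy. It is a step that the two limits leave unreadable from compound 1 to compound 2, so it offers no size or direction to carry forward. No step beyond the scatter can therefore be forecast, and another result at the limit is the likeliest outcome.

The estimated step is a step that the limit leaves unreadable from compound 2 to compound 3.

In this assay, compound 3 is expected near 12000 nM, with an estimated range from 3000 nM to 40000 nM.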

Compound 3, half-maximal inhibitory concentration: > 10000 nM
Compound 3: a limit, no number; the forecaster's own chance of this, stated with the estimate: 75%; the middle value does not contradict the limit.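

For the compounds shown here, compound 3 gives > 10000 nM in this assay, which is a limit and not a number, so no step among compound 1, compound 2 and compound 3 can be read. Whether hydrogen, methoxy and ethoxy differ in effect at all stays open: the limit of > 10000 nM in this assay, at which 3 of the 3 values shown sit.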